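A few compounds are considered here, and "the series" means these few. Any claim that something is new, unique, unknown or untested is made for them only; others in the source may bear on it.

Three compounds have been measured in an in vitro functional assay on cells for agonist activity at Bombesin receptor subtype-3 (Mus musculus), read by luminescence and calcium flux; a higher number here means that more compound is needed for the effect, a lower number that less compound is needed:

Compound 1, `CCCCc1cnc(C(C)Cc2ccc(-c3ccccc3C(=O)O)cc2)[nH]1`: 184 nM
Compound 2, `O=C(O)c1ccccc1-c1ccc(CCc2ncc(Cc3ccccc3F)[nH]2)cc1`: 9.5 nM
Compound 3, `CCCCc1cnc(C(Cc2ccc(-c3ccccc3C(=O)O)cc2)C(C)C)[nH]1`: 2240 nM

Among these three, compound 2 gives the lowest number, and its gap to each of the other two is beyond the scatter, so it is the most potent of the measured set; compound 1 is the nearer of the two and compound 3 the further.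

Compound 4, `O=C(O)c1ccccc1-c1ccc(CCc2ncc(Cc3cccc(F)c3F)[nH]2)cc1`, is the next compound to be tested, and it is built from compound 2 by one change: fluoro in place of hydrogen on an aromatic carbon.

Going by the values given here, only one measured step exists among the three compounds, a 12-fold higher number from compound 1 to compound 3 (1.09 log units; beyond the scatter), and it concerns the saturated chain between the two ring systems, not the benzyl ring. Among the compounds with values here, nothing measured so far touches the ring that is changed here, so there is no direct guide for the added fluoro. A single fluoro added to an aromatic ring is a small change in size, and with no evidence pointing either way the expectation is a step that stays within the scatter: a 1.1-fold higher number from compound 2 to compound 4 (0.02 log units; within the scatter). Compound 4 is therefore estimated at 10 nM, in a range from 3 nM to 35 nM.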

Compound 4, half-maximal effective concentration: 8 nM
Compound 4: the middle estimate sits 1.3-fold (0.10 log units) above what was measured, within the range that was stated.
By their numbers in this assay, from the lowest: compounds 4 and 2 (each within the scatter of the next); then compound 1; then compound 3.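

Changing 2-fluorobenzyl to 2,3-difluorobenzyl gives a 1.2-fold lower number from compound 2 to compound 4 (0.07 log units; within the scatter) in this assay, so this first look at the fluorinated ring shows that the aromatic carbon ortho to a fluoro group can carry a second fluoro with no readable change in the number. Going by these compounds alone, this contrasts with the only earlier step, the swap of methyl for isopropyl on the saturated chain, which gave a 12-fold higher number from compound 1 to compound 3 (1.09 log units; beyond the scatter) and lay beyond the scatter; a single pair of compounds at each place, however, supports no general rule about either part of the molecule. Nothing measured here explains why the added fluoro leaves the number within the scatter.

The compounds shown leave open how a chloro, a methyl, a methoxy or a trifluoromethyl group would read at this same aromatic carbon, and so whether the result holds only for fluoro or for other groups as well. Also open, going by these compounds, is how a plain benzyl group, with no fluoro on its ring, would compare with compound 2 and compound 4 in this assay.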